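The compounds below may be only part of what the source reports. "The series", "measured", "known", "first", "only" and "open" are said of these compounds alone.

Compound 2, with the structure `COc1cc(/C=C/C(=O)/C=C/c2cc(OC)c(OC)c(OC)c2)ccc1OCc1cn(CCOc2cc(=O)oc3ccccc23)nn1`, gives the highest of the three numbers recorded in a functional assay on COLO 205 cells (Homo sapiens) for inhibition, read by sulforhodamine B assay, with a stated time of 48 h, tested at 50 uM; a higher number here means more inhibition of growth at the concentration tested, a lower number less inhibition of growth. In this assay compound 2 gives 86%. Its nearest neighbour is compound 3, with the structure `COc1ccc(/C=C/C(=O)/C=C/c2ccc(OCc3cn(CCCCOc4cc(=O)oc5ccccc45)nn3)c(OC)c2)cc1OC`; compound 3 gives 53%, a result beyond the scatter below compound 2. Compound 1, with the structure `COc1ccc(/C=C/C(=O)/C=C/c2ccc(OCc3cn(CCCCCOc4cc(=O)oc5ccccc45)nn3)c(OC)c2)cc1`, stands furthest away, and in this assay compound 1 gives 30%, again beyond the scatter.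

Compound 4, with the structure `COc1cc(/C=C/C(=O)/C=C/c2ccccc2)ccc1OCc1cn(CCOc2cc(=O)oc3ccccc23)nn1`, has not yet been measured. It differs from compound 2 in one place: phenyl in place of 3,4,5-trimethoxyphenyl on a double-bonded chain carbon bound to a double-bonded chain carbon. For the measured compounds named here, no measured pair shows exactly this change. Among the measured compounds, those carrying fewer methoxy groups, compound 3 and compound 1, score lower than compound 2, although their linker chains differ as well, so the comparison is not clean. On that basis the step of a number 46 percentage points lower from compound 2 to compound 4 (beyond the scatter) is expected to be a fall beyond the scatter. Compound 4 is therefore estimated at 40%, within a range from 15% to 70%.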

Compound 4, percent growth inhibition at one concentration: 54%
Compound 4: middle estimate off by 14 percentage points, on the low side; measured number inside the range.
By their numbers in this assay, from the lowest: compound 1; then compounds 3 and 4 (each within the scatter of the next); then compound 2.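

In this assay, for the compounds shown here, phenyl in place of 3,4,5-trimethoxyphenyl on a double-bonded chain carbon bound to a double-bonded chain carbon gives a number 32 percentage points lower from compound 2 to compound 4 (beyond the scatter), a large step and the first comparison here with only one place changed. It shows that the group at this position matters for growth inhibition at the concentration tested, yet compound 4 still gives 54% with the plain phenyl, so the methoxy groups are not required for inhibition. No measurement at hand explains this step.

The compounds shown leave open how a single methoxy, a hydroxyl or an amine on that ring would score. They also leave the effect of linker length unread, as compounds 1 and 3 differ from compound 2 in more than one place.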